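From Dichlorophenyl to Fluorophenyl on a Shared Core

A few compounds are considered here, and "the series" means these few. Any claim that something is new, unique, unknown or untested is made for them only; others in the source may bear on it.

Of the compounds shown here, three have so far been measured in a functional assay on BGC-823 cells (Homo sapiens) for antiproliferative activity, read by MTT assay, tested at 5 uM; a lower number here means a weaker effect, a higher number a stronger effect of the compound at the concentration tested. Compound 1 `COc1cc(C2=NN(C(C)=O)C(c3c(Cl)cccc3Cl)O2)cc(OC)c1OC` gives 15.9% in this assay, the highest of the three numbers shown, though the gaps to both other compounds lie within the scatter of the method. Compound 2 `COc1cccc(/C=N/NC(=O)c2cc(OC)c(OC)c(OC)c2)c1OC` gives 14.2%, the number closest to compound 1, and compound 3 `COc1ccc(OC)c(/C=N/NC(=O)c2cc(OC)c(OC)c(OC)c2)c1` gives 10.1%, the number furthest from it; neither gap is large enough to count as a real difference. Among the measured compounds shown here, no two of these three compounds differ in a single place, so the data hold no measured step from which the effect of one change can be read.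

Compound 4 `COc1cc(C2=NN(C(C)=O)C(c3cccc(F)c3)O2)cc(OC)c1OC` has not yet been measured. It differs from compound 1 in one place: 3-fluorophenyl in place of 2,6-dichlorophenyl on a saturated ring carbon. For the measured compounds named here, since the three measured compounds sit together within the scatter and no single-change step is known, the author expects the step from compound 1 to compound 4 to be small, a number 1.9 percentage points lower from compound 1 to compound 4 (within the scatter), with no direction that can be claimed beyond the scatter. Compound 4 is therefore estimated at 14% in this assay, with a likely range from 4% to 26%.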

Compound 4, a percentage reported as inhibition, at one concentration (the size of the read-out at that concentration, not a potency): 37.7%
Compound 4: the middle estimate sits 23.7 percentage points below what was measured; the whole stated range lies below it.
By their numbers in this assay, from the lowest: compounds 3, 2 and 1 (each within the scatter of the next); then compound 4.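

In this assay, among the compounds shown here, 3-fluorophenyl in place of 2,6-dichlorophenyl on the saturated ring carbon gives a number 21.8 percentage points higher from compound 1 to compound 4 (beyond the scatter), the first measured single-change step in this set. For the compounds shown here, it shows that the aryl group at this position can move the read-out beyond the scatter while the rest of the molecule stays the same, something the earlier compounds, with no single-change step among them, could not show. The exchange alters the kind of halogen, their number and their places on the phenyl ring all at once, and no measurement here explains the rise or assigns it to any one of these parts of the change.

The compounds shown leave open whether the step depends on the fluorine itself or on the loss of the two chlorines, a question that a plain phenyl group or a chlorophenyl group at the same carbon would help to settle. Also open, going by these compounds, is how a phenyl ring bearing a methoxy group, an amine or a carboxylic acid would read out here, and whether the step holds at other concentrations, since this read-out gives the size of the effect at one concentration and not a potency.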